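The source may report more compounds than this note shows. Statements on the series, on what has been measured and on what is new or still open speak of the compounds shown alone.

Of the compounds shown here, three from this series have been tested in a functional assay on OE19 cells (Homo sapiens) for cytotoxicity, read by MTT assay, with a stated time of 48 h; on this read-out lower numbers stand for stronger inhibition and higher numbers for weaker inhibition. Compound 1, `CC1(C)S[C@@H]2/C(=C\C(=O)c3cc(C(F)(F)F)cc(C(F)(F)F)c3)C(=O)N2[C@H]1C(=O)OC(c1ccccc1)c1ccccc1`, gives 48500 nM. Compound 2, `CCOC(=O)/C=C1/C(=O)N2[C@@H]1SC(C)(C)[C@@H]2C(=O)OC(c1ccccc1)c1ccccc1`, gives 11200 nM, the lowest number among the three. Compound 3, `CC1(C)S[C@@H]2/C(=C\C(=O)OC(c3ccccc3)c3ccccc3)C(=O)N2[C@H]1C(=O)OC(c1ccccc1)c1ccccc1`, gives 21600 nM, which lies within the usual scatter of the number for compound 2, while compound 1 stands clearly higher. The next compound, compound 4, `CC1(C)S[C@@H]2/C(=C\C(=O)c3ccc(C(F)(F)F)cc3)C(=O)N2[C@H]1C(=O)OC(c1ccccc1)c1ccccc1`, has not yet been measured. It differs from compound 2 in one place: 4-(trifluoromethyl)phenyl in place of ethoxy on a carbonyl carbon. Within the data shown here, no pair of measured compounds shares this exact change, so no measured step guides it; the account expects a move toward weaker inhibition, estimated as a 2.2-fold higher number from compound 2 to compound 4 (0.35 log units; beyond the scatter) in this assay, perhaps beyond the scatter, because compound 1 sits at 48500 nM. For compound 4 the expected result in this assay is 25000 nM, with a range from 8000 nM to 80000 nM.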

Compound 4, half-maximal inhibitory concentration: 15600 nM
Compound 4: middle estimate off by 1.6-fold (0.20 log units), on the high side, within the range that was stated.
By their numbers in this assay, from the lowest: compounds 2, 4 and 3 (each within the scatter of the next); then compound 1.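

Among these compounds, this is the first readable step at this position: in this assay, 4-(trifluoromethyl)phenyl in place of ethoxy on a carbonyl carbon gives a 1.4-fold higher number from compound 2 to compound 4 (0.14 log units; within the scatter), so the exchange of an ethoxy for a larger aromatic group leaves the number within the scatter. An ester carbonyl is therefore not required here for activity at this level in this assay. Nothing available explains this result.

The compounds shown leave open how an amine or a longer alkyl chain on this carbonyl carbon would read.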